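Three inactive amides and a bulkier fourth

This account rests on a few compounds, and the source may have more. Where it says the series, first, only, none or still open, it means among the compounds named here.

Compound 1, `Cc1cc(Cc2cccc(Cl)c2)c(=O)n(CC(=O)Nc2ccc(Br)cc2)n1`, reaches only a limit in a functional assay on HL-60 cells (Homo sapiens), read by calcium flux (on this read-out lower numbers stand for an effect already at smaller amounts and higher numbers for an effect only at larger amounts of compound), namely > 50000 nM.
Compound 2, `Cc1cc(Cc2cccnc2)c(=O)n(CC(=O)Nc2ccc(Br)cc2)n1`, also gives only a limit in this assay, > 50000 nM.
Compound 3, `Cc1cc(N)c(=O)n(CC(=O)Nc2ccc(Br)cc2)n1`, likewise gives only a limit in this assay, > 50000 nM.

Compound 3 therefore stands where every measured compound stands: at the assay limit, as the limit of > 50000 nM in this assay, at which 3 of the 3 values shown sit, records. For the measured compounds named here, none of the measured steps can be read in size, neither a step that the two limits leave unreadable from compound 1 to compound 2, nor a step that the two limits leave unreadable from compound 1 to compound 3, nor a step that the two limits leave unreadable from compound 2 to compound 3.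

Compound 4, `Cc1cc(NC(=O)c2ccc(Br)cc2)c(=O)n(CC(=O)Nc2ccc(Br)cc2)n1`, is not yet measured. It differs from compound 3 by (4-bromophenyl)carbonyl in place of hydrogen on a nitrogen on an aromatic ring. Going by the values given here, the steps so far bear on this change only insofar as every one of them leaves the assay limit untouched; no step gives a direction or a size. He therefore expects the step of a number no higher from compound 3 to compound 4 (the limit leaves the size open) to be the most likely outcome, with the limit again the probable report. His estimate for compound 4 in this assay is 50000 nM, between 10000 nM and 200000 nM.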

Compound 4, half-maximal effective concentration: > 50000 nM
Compound 4 was reported as a limit; the forecaster's own chance of this, stated with the estimate: 75%; the middle value sits exactly at the limit.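

Compound 3 and compound 4 both end at a limit, so no new step can be read from them in this assay: the limit of > 50000 nM in this assay, at which 4 of the 4 values shown sit.

The compounds shown leave open how large any of these changes is, and which change on the shared core, if any, would give a measurable value.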